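This account rests on a few compounds, and the source may have more. Where it says the series, first, only, none or still open, it means among the compounds named here.

In a toxicity assay on THP-1 cells (Homo sapiens) for inhibition (a higher number here means that more compound is tolerated, a lower number that less compound is tolerated), compound 1 (`Cn1c(-c2ccccc2)cnc1NC(=O)c1ccc(F)cc1`) gives > 100000 nM as its reading, and that is a limit of the assay. Compound 3 (`Cn1c(-c2ccc(C#N)cc2)cnc1NC(=O)c1ccc(F)cc1`) stands at > 50000 nM as its reading, which is also a limit and not a number. Compound 2 (`Cn1c(-c2ccc(Cl)cc2)cnc1NC(=O)c1ccc(F)cc1`) gives 37000 nM as a true number. Chloro in place of hydrogen on an aromatic carbon brings an at least 2.7-fold lower number from compound 1 to compound 2 (0.43 log units; beyond the scatter) in this small series. Cyano in place of chloro brings an at least 1.3-fold higher number from compound 2 to compound 3 (0.13 log units; that floor lies within the scatter) as its step, while cyano in place of hydrogen gives a step that the two limits leave unreadable from compound 1 to compound 3 as its step.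

Compound 4 (`Cn1c(-c2ccc([N+](=O)[O-])cc2)cnc1NC(=O)c1ccc(F)cc1`) carries nitro in place of cyano on an aromatic carbon, para to a large group (nitro in place of cyano on an aromatic carbon). Going by the values given here, no measured step brings in nitro, so the best guide is compound 2 with 37000 nM as the only true number for a compound with a group at this place. A small fall or none beyond the scatter is expected, and the estimated change is an at least 1.2-fold lower number from compound 3 to compound 4 (0.09 log units; that floor lies within the scatter) on that basis. In this assay the expected value for compound 4 is 40000 nM with an estimated range of 15000 nM to 100000 nM as its bounds.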

Compound 4, half-maximal cytotoxic concentration: > 50000 nM
Compound 4 gave a limit, no number (the forecaster's own chance of this, stated with the estimate: 50%); middle value at least 1.2-fold (0.09 log units) from the limit.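

In this assay, nitro in place of cyano leaves compound 4 at a limit and not a number, so a second group at this place, on an aromatic carbon para to a large group, gives no true reading: the limit of > 50000 nM in this assay, at which 2 of the 4 values shown sit. Nitro in place of chloro brings an at least 1.3-fold higher number from compound 2 to compound 4 (0.13 log units; that floor lies within the scatter), which means that the floor of this step does not yet separate compound 4 from compound 2, and chloro remains the only group at this place with a true number. The steps from compound 1 and from compound 3 to compound 4 cannot be read.

From the compounds shown here alone, whether compound 3 and compound 4 differ at all stays open, as does how either compares with compound 1. Also open, going by these compounds, is how an amine or a carboxylic acid at this place would read in this assay.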